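The compounds below may be only part of what the source reports. "The series", "measured", "known", "first", "only" and "open" are said of these compounds alone.

Measured:
compound 1 `CCCCC(Sc1ccc(OCCCOc2ccc(-c3ccccc3)cc2)cc1)C(=O)O` — 3500 nM
compound 2 `Cc1cccc(OCCCOc2ccc(CCC(=O)O)cc2)c1C` — > 10000 nM, a limit
compound 3 `CCCCC(Sc1ccc(OCCCOc2cccc(C)c2)cc1)C(=O)O` — > 10000 nM, a limit

In an assay for inhibition of Polyunsaturated fatty acid 5-lipoxygenase (Homo sapiens), read by HPLC, with a stated time of 10 min (a lower number here means a stronger inhibitor, a higher number a weaker inhibitor), compound 1 gives 3500 nM. For compound 2 the assay reports only a limit, > 10000 nM. Compound 3 likewise returns only a limit, > 10000 nM, so compound 3 sits at the limit of > 10000 nM in this assay, at which 2 of the 3 values shown sit, and no number is known for it. Among the compounds with values here, no measured pair differs in a single place, so no step size can be taken from the data. Compound 4 `CCCCC(Sc1ccc(OCCCOc2ccccc2OC)cc1)C(=O)O` differs from compound 3 by 2-methoxyphenyl in place of 3-methylphenyl on an oxygen on a saturated carbon. With compound 3 at the limit, the change is expected to stay within scatter or shift slightly; the step from compound 3 to compound 4 is estimated as an at least 1.1-fold lower number from compound 3 to compound 4 (0.04 log units; that floor lies within the scatter). Compound 4 is expected to give 9000 nM, within 3000 nM to 30000 nM.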

Compound 4, half-maximal inhibitory concentration: > 10000 nM
Compound 4: only a limit was reported; the forecaster's own chance of this, stated with the estimate: 55%; middle value at least 1.1-fold (0.04 log units) from the limit.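

In this assay compound 3 and compound 4 each give only a limit, so no step between them can be read: the limit of > 10000 nM in this assay, at which 3 of the 4 values shown sit.

The compounds shown leave open whether 2-methoxyphenyl in place of 3-methylphenyl changes inhibition at all.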